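Aminomethylpyridine on the thiazole core: an expected binding shift

The source may report more compounds than this note shows. Statements on the series, on what has been measured and on what is new or still open speak of the compounds shown alone.

Of the compounds shown here, three that share a core have been measured in an in vitro assay on HEK385-7 cells for displacement of a labelled ligand from prostaglandin D2 receptor 2 (Homo sapiens); a lower number here means a stronger inhibitor, a higher number a weaker inhibitor. Compound 1 `O=C(O)Cc1sc(C(c2ccccc2)c2ccccc2)nc1-c1ccc(C(F)(F)F)cc1` gives 1100 nM. Compound 2 `O=C(O)Cc1sc(C(c2ccc(F)cc2)c2ccc(F)cc2)nc1-c1ccco1` gives 18 nM. Compound 3 `O=C(O)Cc1sc(C(c2ccc(F)cc2)c2ccc(F)cc2)nc1-c1ccncc1` gives 5.3 nM, the lowest of the three numbers, and the gap to compound 1 lies well beyond the scatter. Among the measured compounds shown here, the one single-point step known so far, a 3.4-fold lower number from compound 2 to compound 3 (0.53 log units; beyond the scatter), swaps one aromatic ring for another at the same place on the core and is modest in size.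

Compound 4 `Cc1cc(-c2nc(C(c3ccc(F)cc3)c3ccc(F)cc3)sc2CC(=O)O)cnc1N` differs from compound 3 in one place: 6-amino-5-methylpyridin-3-yl in place of pyridin-4-yl on an aromatic carbon. This adds a hydrogen-bond donor and a second acceptor to a ring of the kind already present. For the measured compounds named here, no measured pair isolates this particular change, so the step from compound 2 to compound 3 is only an indirect guide to how much a change at this position can move the number. The expectation for compound 4 is therefore a step close to the scatter, a 1.1-fold higher number from compound 3 to compound 4 (0.05 log units; within the scatter), in either direction. Compound 4 is estimated at 6 nM, within a range of 2 nM to 25 nM.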

Compound 4, half-maximal inhibitory concentration: 880 nM
Compound 4: the middle estimate sits 150-fold (2.17 log units) below what was measured, and the stated range ends below it.
By their numbers in this assay, from the lowest: compound 3; then compound 2; then compounds 4 and 1 (each within the scatter of the next).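

Among the compounds shown here, at this aromatic carbon of the shared core, next to the ring nitrogen, a change from one aromatic ring to another can move the number far more than the earlier compounds showed: in this assay there is a 170-fold higher number from compound 3 to compound 4 (2.22 log units; beyond the scatter), a much larger step than a 3.4-fold lower number from compound 2 to compound 3 (0.53 log units; beyond the scatter). Measured against furan-2-yl, 6-amino-5-methylpyridin-3-yl also gives a 49-fold higher number from compound 2 to compound 4 (1.69 log units; beyond the scatter), so ring swaps here can shift the number in either direction. No measurement at hand accounts for this large rise.

The entering group differs from pyridin-4-yl in three ways at once: its amine, its methyl and the ring position through which it attaches. Which of these carries the step stays open, and a pyridin-3-yl ring bearing only the amine or only the methyl would begin to separate them.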